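From 3-Cyanophenyl to 4-(Trifluoromethyl)phenyl

The source may report more compounds than this note shows. Statements on the series, on what has been measured and on what is new or still open speak of the compounds shown alone.

In a functional assay on HeLa cells (Homo sapiens) for inhibition, read by CCK-8 assay, with a stated time of 48 h (on this read-out lower numbers stand for stronger inhibition and higher numbers for weaker inhibition), compound 1 `COc1cc(-c2ccnc3cc(-c4c[nH]c5ccccc45)nn23)cc(OC)c1OC` gives 195 nM, and compound 2 `COc1cc(-c2ccnc3cc(-c4ccc(Cl)cc4)nn23)cc(OC)c1OC` gives 1490 nM. Compound 3 `COc1cc(-c2ccnc3cc(-c4cccc(C#N)c4)nn23)cc(OC)c1OC` reads > 10000 nM, which is a limit of the assay and not a number. Compound 4 `COc1cc(-c2ccnc3cc(-c4ccc(C(F)(F)F)cc4)nn23)cc(OC)c1OC` carries 4-(trifluoromethyl)phenyl in place of 3-cyanophenyl on an aromatic carbon. All measured steps change this same place: a 7.6-fold higher number from compound 1 to compound 2 (0.88 log units; beyond the scatter) and an at least 51-fold higher number from compound 1 to compound 3 (1.70 log units; beyond the scatter). The closest is an at least 6.7-fold higher number from compound 2 to compound 3 (0.82 log units; beyond the scatter), which also leaves 3-cyanophenyl's counterpart as a 4-substituted phenyl. Compound 4 is therefore expected to lie nearer compound 2 at 1490 nM, a modest step to a lower number in this assay. The expected step is an at least 4.0-fold lower number from compound 3 to compound 4 (0.60 log units; beyond the scatter). For compound 4, the estimate is 2500 nM, within an expected range of 900 nM to 8000 nM.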

Compound 4, half-maximal inhibitory concentration: 1840 nM
Estimate against measurement, compound 4: 1.4-fold (0.13 log units) above, within the range that was stated.
By their numbers in this assay, from the lowest: compound 1; then compounds 2 and 4 (each within the scatter of the next). At a limit, above all of these: compound 3.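

The change to 4-(trifluoromethyl)phenyl gives an at least 5.4-fold lower number from compound 3 to compound 4 (0.73 log units; beyond the scatter), so a measurable value returns at this position. Trifluoromethyl in place of chloro gives a 1.2-fold higher number from compound 2 to compound 4 (0.09 log units; within the scatter), so these two groups are not told apart here, while 4-(trifluoromethyl)phenyl remains separated from the 1H-indol-3-yl group, with a 9.4-fold higher number from compound 1 to compound 4 (0.97 log units; beyond the scatter). The first of these steps is only a bound, since compound 3 stands at a limit of the assay and not at a number: the limit of > 10000 nM in this assay, at which 1 of the 4 values shown sits.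

The compounds shown leave open whether a phenyl ring bearing an amine or a carboxylic acid would read nearer compound 1 or compound 2.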